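Ortho Branching Returns to the Aryl Group on the Ring Nitrogen

A few compounds are considered here, and "the series" means these few. Any claim that something is new, unique, unknown or untested is made for them only; others in the source may bear on it.

Compound 2 `Cc1ccc(-n2nc(C)c3c2NC(=O)[C@H](C)S[C@@H]3c2ccc(Oc3ccccc3)cc2)cc1` gives 11% in an assay on isolated protein for agonist activity at Bile acid receptor (Homo sapiens), read by AlphaScreen, with a stated time of 30 min (on this read-out higher numbers stand for larger maximal responses and lower numbers for smaller maximal responses), the lower of the two numbers measured, with compound 1 `CCCc1ccccc1-n1nc(C)c2c1NC(=O)[C@H](C)S[C@@H]2c1ccc(Oc2ccccc2)cc1` at 240%. Compound 3 `Cc1nn(-c2ccccc2C(C)C)c2c1[C@@H](c1ccc(Oc3ccccc3)cc1)S[C@@H](C)C(=O)N2` differs from compound 2 by 2-isopropylphenyl in place of 4-methylphenyl on an aromatic nitrogen. Going by the values given here, the one relevant step, a number 229 percentage points lower from compound 1 to compound 2 (beyond the scatter), runs the other way, from a 2-propylphenyl to the 4-methylphenyl; 2-isopropylphenyl resembles 2-propylphenyl far more than 4-methylphenyl, so a large rise in this assay is expected, though no measured pair reports an isopropyl directly. Compound 3 is therefore estimated at 180% (range 60% to 300%), an expected step of a number 169 percentage points higher from compound 2 to compound 3 (beyond the scatter).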

Compound 3, largest response reached (reported as efficacy), in percent of the reference or control that the assay uses: 174%
For compound 3 the middle estimate is 6 percentage points above the measured one, and the stated range covers the measured number.
By their numbers in this assay, from the lowest: compound 2; then compound 3; then compound 1.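

In this assay, 2-isopropylphenyl recovers most of the response lost with 4-methylphenyl, giving a number 163 percentage points higher from compound 2 to compound 3 (beyond the scatter) on this aromatic nitrogen. The exact chain on the aryl group also counts, since isopropyl in place of propyl gives a number 66 percentage points lower from compound 1 to compound 3 (beyond the scatter) and a high response does not depend on the propyl chain alone. No measured evidence explains either step. On these data alone, it remains open how a 2-ethylphenyl or 2-methoxyphenyl group would read here, and whether a 4-isopropylphenyl group would keep the high response, which would separate the chain from its place on the ring.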